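The compounds below may be only part of what the source reports. "The series", "measured", "known", "first", "only" and "open" are said of these compounds alone.

Measured so far in an ADME assay on RAW264.7 cells (Mus musculus) for cytotoxicity, read by MTT assay, with a stated time of 24 h, in the presence of a further agent that is not named here; a higher number here means a weaker inhibitor, a lower number a stronger inhibitor:
Compound 1 `C=CCCOc1ccc(C(O)C2OC(=O)c3c(OC)cc(OC)cc32)cc1`: > 40000 nM
Compound 2 `COc1cc(OC)c2c(c1)C(C(O)c1ccc(OCc3ccccc3)cc1)OC2=O`: > 40000 nM

Both entries are limits of the assay and not numbers. Compound 2 gives > 40000 nM, which is such a limit, so its place can be stated only in that form. It shares this position with compound 1, and the full record so far reads: the limit of > 40000 nM in this assay, at which 2 of the 2 values shown sit.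

The next compound to be tested is compound 3 `COc1cc(OC)c2c(c1)C(C(O)c1ccc(OCc3ccc(F)cc3)cc1)OC2=O`. It differs from compound 2 by a single change: fluoro in place of hydrogen on an aromatic carbon. In words, this is fluoro in place of hydrogen on an aromatic carbon, turning benzyloxy into (4-fluorobenzyl)oxy.

Among the compounds with values here, only one measured step is available, a step that the two limits leave unreadable from compound 1 to compound 2. Within the data shown here, it offers no size to carry over to the new change, and no measured compound yet carries the fluoro group. Among the measured compounds shown here, the only guide for compound 3 is therefore its parent, compound 2 at > 40000 nM, and no shift beyond the usual scatter is expected in this assay. The expected step is a step that the limit leaves unreadable from compound 2 to compound 3. A further limit is the most likely report. For compound 3 the estimated value is 50000 nM, with an expected range from 25000 nM to 100000 nM.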

Compound 3, half-maximal inhibitory concentration: > 40000 nM
Compound 3: no number, only a limit; the forecaster's own chance of this, stated with the estimate: 85%; the middle value is on the limit's open side.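

Compound 3, like compound 1 and compound 2, gives only a limit and not a number in this assay, so no step among the three can be read: the limit of > 40000 nM in this assay, at which 3 of the 3 values shown sit.

The compounds shown leave open whether the fluoro group, or any other difference among them, changes the half-maximal inhibitory concentration at all.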